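The source may hold more compounds than are shown below. What is called first, only, known or untested is meant among the compounds shown, and "the series" means these compounds.

Working notes on the series in a functional assay on HL-60 cells (Homo sapiens) for antiproliferative activity, read by MTT assay, with a stated time of 72 h; on this read-out lower numbers stand for stronger inhibition and higher numbers for weaker inhibition. Compound 1 `COc1cc(-c2ncnn2-c2cccc(F)c2)cc(OC)c1OC` reads > 10000 nM, which is a limit and not a number. Compound 2 `COc1cc(-c2ncnn2-c2ccc(Cl)cc2)cc(OC)c1OC` reads > 10000 nM, again a limit. Going by the values given here, compound 3 `COc1ccc(-n2ncnc2-c2cc(OC)c(OC)c(OC)c2)cc1`, at 6200 nM, holds the only true number so far, and the rest of the series stands at the limit of > 10000 nM in this assay, at which 2 of the 3 values shown sit.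

Compound 4 `COc1cc(-c2ncnn2-c2ccc(Cl)c(Cl)c2)cc(OC)c1OC` carries 3,4-dichlorophenyl in place of 4-methoxyphenyl on an aromatic nitrogen. Among the compounds with values here, two measured steps bear on this change: an at least 1.6-fold lower number from compound 1 to compound 3 (0.20 log units; that floor lies within the scatter) and an at least 1.6-fold lower number from compound 2 to compound 3 (0.20 log units; that floor lies within the scatter). Both are only floors, and neither floor clears the scatter. The step that the two limits leave unreadable from compound 1 to compound 2 adds nothing on size. The closest comparison is the chlorinated compound 2, so the change is read in reverse of the second step, and a modest move toward weaker inhibition is expected. The expected change is a 1.8-fold higher number from compound 3 to compound 4 (0.25 log units; within the scatter). A reading at the limit is the likeliest outcome. For compound 4 the estimated value is 11000 nM, with an expected range from 5000 nM to 30000 nM.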

Compound 4, half-maximal inhibitory concentration: > 10000 nM
Compound 4 gave a limit, no number; the forecaster's own chance of this, stated with the estimate: 70%; the middle value lies beyond the limit too.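

In this assay the 3,4-dichlorophenyl group on the aromatic nitrogen gives no number, and compound 4 reads > 10000 nM as a limit and not a number. As far as these compounds go, putting 3,4-dichlorophenyl in place of 4-methoxyphenyl gives an at least 1.6-fold higher number from compound 3 to compound 4 (0.20 log units; that floor lies within the scatter) and the true size of the change stays unknown. Going by these compounds alone, the steps among compound 1, compound 2 and compound 4 cannot be read, so the added chloro on the aromatic carbon shows no measurable effect, and compound 3 remains the only compound with a number: the limit of > 10000 nM in this assay, at which 3 of the 4 values shown sit.

The compounds shown leave open how far the reading lies beyond the limit for each halogenated phenyl group. They also leave open how an amine or a hydroxyl group on this phenyl ring would read in this assay.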